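Phenoxy at the Saturated Ring Carbon: Expecting Compound 3

The compounds below may be only part of what the source reports. "The series", "measured", "known", "first", "only" and "open" are said of these compounds alone.

Compound 1 `COc1cc(N2C(=O)C(O)C2c2ccc(SC)cc2)cc(OC)c1OC`: 15 nM
Compound 2 `C=CC1C(=O)N(c2cc(OC)c(OC)c(OC)c2)C1c1ccc(SC)cc1`: 113 nM

Among the compounds with values here, in a functional assay on HT-29 cells (Homo sapiens) for inhibition, read by sulforhodamine B assay, with a stated time of 72 h (on this read-out higher numbers stand for weaker inhibition and lower numbers for stronger inhibition), compound 2 stands at the higher of the two numbers, and the only measured step, a 7.5-fold higher number from compound 1 to compound 2 (0.88 log units; beyond the scatter), concerns the same saturated ring carbon. Compound 3 `COc1cc(N2C(=O)C(Oc3ccccc3)C2c2ccc(SC)cc2)cc(OC)c1OC` carries phenoxy in place of vinyl on a saturated ring carbon. Within the data shown here, no measured pair sets phenoxy against vinyl, so the hydroxy of compound 1 gives only indirect guidance, the oxygen-bearing group there having given the lower number. Compound 3 is therefore expected to give about 150 nM (range 30 nM to 800 nM), an expected step of a 1.3-fold higher number from compound 2 to compound 3 (0.12 log units; within the scatter) that should stay within the scatter or only slightly beyond it.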

Compound 3, half-maximal inhibitory concentration: 336 nM
Compound 3: the middle estimate sits 2.2-fold (0.35 log units) below what was measured, within the range that was stated.
By their numbers in this assay, from the lowest: compound 1; then compound 2; then compound 3.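

In this assay, phenoxy in place of vinyl on the saturated ring carbon brings a 3.0-fold higher number from compound 2 to compound 3 (0.47 log units; beyond the scatter), so an oxygen attached at this carbon does not by itself give the lower number. Within the data shown here, putting phenyl on the hydroxy oxygen brings a 22-fold higher number from compound 1 to compound 3 (1.35 log units; beyond the scatter), the largest step among the three compounds, and compound 1, with its hydroxy, remains the one with the lowest number. No evidence at hand accounts for these steps. Open, going by these compounds, is whether a methoxy or an amine on this carbon would stay close to compound 1.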